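The source may hold more compounds than are shown below. What is called first, only, known or untested is meant among the compounds shown, and "the series" means these compounds.

Measured so far in an assay for inhibition of DNA topoisomerase 1 (Homo sapiens), with a stated time of 30 min, tested at 100 uM; on this read-out higher numbers stand for a stronger effect at the one concentration tested and lower numbers for a weaker effect:
compound 1 `O=C(/C=C/c1cccs1)c1ccccc1OCC1CO1` gives 11.1%;
compound 2 `O=C(/C=C/c1ccc(OCC2CO2)cc1)c1ccco1` gives 0%;
compound 3 `O=C(/C=C/c1ccc(OCC2CO2)cc1)c1cccs1` gives 34.1%.

Compound 2 stands lowest of the three numbers in this assay. Compound 1 is the nearest to it and compound 3 the furthest, both beyond the scatter. Within the data shown here, the only step between two compounds that differ in one place is a number 34.1 percentage points higher from compound 2 to compound 3 (beyond the scatter); it is large, and it concerns the ring on the carbonyl carbon.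

Compound 4 `O=C(/C=C/c1ccc(OCC(O)CCl)cc1)c1ccco1` differs from compound 2 at the other end of the molecule: 2-chloro-1-hydroxyethyl in place of oxiran-2-yl on a saturated chain carbon bound to an oxygen on an aromatic ring. Among the measured compounds shown here, no measured pair shows this change at a saturated chain carbon bound to an oxygen on an aromatic ring, so the step from compound 2 to compound 3 does not bear on it, and the series gives no measure of its size. Compound 2 already stands at the foot of the range seen, which leaves little room downward. The expected step is therefore one near zero or a small rise, not beyond the scatter, written as a number 5 percentage points higher from compound 2 to compound 4 (within the scatter). Compound 4 is estimated at 5% in this assay, with a range from 0% to 20%.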

Compound 4, a percentage reported as inhibition, at one concentration (the size of the read-out at that concentration, not a potency): 1.8%
For compound 4 the middle estimate is 3.2 percentage points above the measured one; low and high end bracket the measured number.
By their numbers in this assay, from the lowest: compounds 2, 4 and 1 (each within the scatter of the next, the first and the last beyond it); then compound 3.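

In this assay, the change on a saturated chain carbon bound to an oxygen on an aromatic ring now has a measured size: a number 1.8 percentage points higher from compound 2 to compound 4 (within the scatter). With (oxiran-2-yl)methoxy replaced by 3-chloro-2-hydroxypropoxy, the three-membered ring gives way to an open chain carrying a hydrogen-bond donor and a chlorine, yet this pair shows no gain beyond the scatter on the furan-2-yl side. Compound 2 gives 0%, so a loss from this change could not show in this pair, and the step says nothing about whether the oxiran-2-yl group contributes to the read-out; no data at hand offer an explanation for this result.

As far as these compounds go, it remains open whether the same change would carry over to the thiophen-2-yl side, where compound 3 gives 34.1% and a fall could be read. Also open, from the compounds shown here alone, is what this position would give with an amine or a carboxylic acid in place of the chlorine of the 3-chloro-2-hydroxypropyl group, or with a longer chain.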